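One More Group Swap in a Level Series

This account rests on a few compounds, and the source may have more. Where it says the series, first, only, none or still open, it means among the compounds named here.

- Compound 1 `O=C(N/N=C/c1cccc(Cl)c1Cl)Nc1cc2c(Nc3ccc(F)c(Cl)c3)ncnc2cc1O[C@H]1CCOC1` gives 27400 nM in a functional assay on PC-3 cells (Homo sapiens) for cytotoxicity, read by MTT assay, with a stated time of 72 h; on this read-out lower numbers stand for stronger inhibition and higher numbers for weaker inhibition
- Compound 2 `COc1cc2ncnc(Nc3ccc(F)c(Cl)c3)c2cc1NC(=O)N/N=C/c1ccc(F)cc1Cl` gives 25700 nM in this assay
- Compound 3 `COc1cc2ncnc(Nc3ccc(F)c(Cl)c3)c2cc1NC(=O)N/N=C/c1cccc(Cl)c1Cl` gives 24400 nM in this assay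

In this assay compound 3 stands level with the other two, showing a 1.1-fold lower number from compound 2 to compound 3 (0.02 log units; within the scatter) and a 1.1-fold lower number from compound 1 to compound 3 (0.05 log units; within the scatter) as its steps. Compound 4 `COc1cc2ncnc(Nc3ccc(F)c(Cl)c3)c2cc1NC(=O)N/N=C/c1cc(Br)c(O)c(Br)c1` brings the change 3,5-dibromo-4-hydroxyphenyl in place of 2,3-dichlorophenyl on a carbon with a double bond to nitrogen with 3,5-dibromo-4-hydroxyphenyl in place of 2,3-dichlorophenyl on a carbon with a double bond to nitrogen. Going by the values given here, only compound 2 and compound 3 bear directly on this place, through a 1.1-fold lower number from compound 2 to compound 3 (0.02 log units; within the scatter) as the one measured change there. The other step concerns a group on an oxygen on an aromatic ring. Going by these compounds, no shift beyond the scatter is therefore expected, and the estimate is a 1.1-fold lower number from compound 3 to compound 4 (0.04 log units; within the scatter) with a wide margin, since this group is untested. For compound 4 the estimated value is 22000 nM with an expected range of 9000 nM to 50000 nM in this series.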

Compound 4, half-maximal inhibitory concentration: 41500 nM
Estimate against measurement, compound 4: 1.9-fold (0.28 log units) below, within the range that was stated.
By their numbers in this assay, from the lowest: compounds 3, 2, 1 and 4 (each within the scatter of the next).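

In this assay, placing 3,5-dibromo-4-hydroxyphenyl on a carbon with a double bond to nitrogen gives a 1.7-fold higher number from compound 3 to compound 4 (0.23 log units; within the scatter) in place of 2,3-dichlorophenyl and a 1.6-fold higher number from compound 2 to compound 4 (0.21 log units; within the scatter) in place of 2-chloro-4-fluorophenyl. This place therefore accepts bromine and a hydroxyl on the ring, not only chlorine and fluorine, with no step beyond the scatter among these three groups. Nothing available explains these steps. Going by these compounds, whether an amine or a carboxylic acid on this ring would move the number beyond the scatter remains open. So does whether 3,5-dibromo-4-hydroxyphenyl would read the same with oxolan-3-yl in place of methyl on the oxygen on the aromatic ring.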